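The compounds below may be only part of what the source reports. "The series", "measured", "known", "first", "only" and "open" are said of these compounds alone.

Of the compounds shown here, two sharing a core have been tested so far in a functional assay on H22 cells (Mus musculus) for inhibition, read by MTT assay, with a stated time of 24 h; a higher number here means a weaker inhibitor, a lower number a stronger inhibitor. Compound 1 `O=[N+]([O-])c1cccc(CNc2cc(Br)cc3[nH]ncc23)c1` gives > 20000 nM, which is a limit of the assay and not a number. Among the measured compounds shown here, compound 2 `O=[N+]([O-])c1cc(Cl)ccc1CNc1cc(C(F)(F)F)cc2[nH]ncc12` gives 10300 nM, so it is the only compound with a true number to work from. The two differ in more than one place, so their values do not show what any single change does.

Compound 3 `O=[N+]([O-])c1ccccc1CNc1cc(C(F)(F)F)cc2[nH]ncc12` has not yet been measured. It differs from compound 2 in one place: hydrogen in place of chloro on an aromatic carbon. In short, hydrogen stands in place of chloro on an aromatic carbon.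

For the measured compounds named here, no measured pair shows this swap directly, so any forecast here is uncertain. Starting from compound 2 at 10300 nM, a small step towards weaker inhibition is expected, of about the size of the usual scatter. The result could also come back as a limit rather than a number. The expected change is a 1.5-fold higher number from compound 2 to compound 3 (0.16 log units; within the scatter). For compound 3 the estimate is 15000 nM, with an expected range from 6500 nM to 32000 nM.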

Compound 3, half-maximal inhibitory concentration: 9010 nM
Estimate against measurement, compound 3: 1.7-fold (0.22 log units) above; low and high end bracket the measured number.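

In this assay, among the compounds shown here, hydrogen in place of chloro on the ring that carries the nitro group gives a 1.1-fold lower number from compound 2 to compound 3 (0.06 log units; within the scatter), and this is the first change that can be read alone, since compound 1 and compound 2 differ in more than one place. At this position, meta to a nitro group and para to a large group, the step lies within the usual scatter, so the assay does not tell chloro and hydrogen apart here, and the single chlorine atom shows no measurable part in the number. Compound 1 still gives no number to compare with, as its value is a limit of the assay: the limit of > 20000 nM in this assay, at which 1 of the 3 values shown sits.

The compounds shown leave open whether this position tolerates every group or only these two, and a methoxy group, an amine or a carboxylic acid in the same place would test that more sharply than one atom swapped for hydrogen. For the compounds shown here, also open is what the nitro group, the trifluoromethyl group or the bromo group of compound 1 each contribute, as no single step here changes any of them.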